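The source may report more compounds than this note shows. Statements on the series, on what has been measured and on what is new or still open speak of the compounds shown alone.

Measured so far:
compound 1, `CCOC(=O)CCCCCOc1cccc(CN(C(=O)c2ccc(-c3cccc(NC(C)=O)c3)cc2)C(C)C)c1`: > 26000 nM
compound 2, `CCOC(=O)CCCCCOc1cccc(CN(C(=O)c2ccc(-c3ccco3)cc2)C(C)C)c1`: > 26000 nM

In an ADME assay on HepG2 cells (Homo sapiens) for cytotoxicity, read by CellTiter-Glo and resazurin assay, with a stated time of 72 h (a lower number here means that less compound is needed, a higher number that more compound is needed for the effect), compound 2 gives > 26000 nM, which is a limit of the assay and not a number. Compound 1 likewise sits at > 26000 nM, again a limit rather than a measured value. The step that the two limits leave unreadable from compound 1 to compound 2 is therefore unreadable, because the limit of > 26000 nM in this assay, at which 2 of the 2 values shown sit, places both values shown at the same limit.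

The next compound is compound 3, `CCOC(=O)CCCCCOc1cccc(CN(C(=O)c2ccc(-c3ccc4[nH]ccc4c3)cc2)C(C)C)c1`. It differs from compound 2 by 1H-indol-5-yl in place of furan-2-yl on an aromatic carbon.

Going by the values given here, no measured step bears on this change in a readable way, since the only step available, from compound 1 to compound 2, cannot be sized. What the data do show is that two different groups at this position both left the compound at the limit of this assay. The expectation is that compound 3 behaves in the same way, with the step that the limit leaves unreadable from compound 2 to compound 3 expected to stay within the scatter. Compound 3 is therefore estimated at 30000 nM in this assay. The estimated range for compound 3 runs from 12000 nM to 80000 nM, most likely reported again as a limit.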

Compound 3, half-maximal effective concentration: > 26000 nM
Compound 3 gave a limit, no number; the forecaster's own chance of this, stated with the estimate: 80%; the middle value lies beyond the limit too.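

In this assay compound 3 gives > 26000 nM as a limit of the assay, not a number. Going by these compounds alone, no step among compound 1, compound 2 and compound 3 can be read, because all three share one limit: the limit of > 26000 nM in this assay, at which 3 of the 3 values shown sit. The compounds shown leave open how far each lies beyond that limit, and whether these three groups differ at all in this assay.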